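A few compounds are considered here, and "the series" means these few. Any claim that something is new, unique, unknown or untested is made for them only; others in the source may bear on it.

Measured in an ADME assay on the whole organism for pharmacokinetics, with Mus musculus as the target, at a dose of 10 mg/kg by the oral route (a lower number here means less compound in the circulation, a higher number more compound in the circulation at the dose given), so far:
compound 1 `CC1=C(c2ccc(C#N)cc2)C(c2ccc(OC[C@H](C)N3CC[C@@H](C)C3)cc2)Oc2ccc(O)cc21`: 2000 ng.h/mL
compound 2 `CC1=C(c2cccc(O)c2)C(c2ccc(OC[C@H](C)N3CC[C@@H](C)C3)cc2)Oc2ccc(O)cc21`: 590 ng.h/mL

For the measured compounds named here, compound 2, at 590 ng.h/mL, holds the lower of the two numbers in this assay and lies beyond the scatter from compound 1, its only neighbour. Compound 3 `CC1=C(c2ccccc2)C(c2ccc(OC[C@H](C)N3CC[C@@H](C)C3)cc2)Oc2ccc(O)cc21` departs from compound 2 by a single change, (hydrogen in place of hydroxy on an aromatic carbon), which is hydrogen in place of hydroxy on an aromatic carbon, or 3-hydroxyphenyl to phenyl. Going by the values given here, one measured step bears on this group: a 3.4-fold lower number from compound 1 to compound 2 (0.53 log units; beyond the scatter), a modest step that lies beyond the scatter. Among the compounds with values here, that step swapped a 4-cyanophenyl for the 3-hydroxyphenyl, so it does not isolate the hydroxy, and no measured pair compares hydroxy with hydrogen directly. Compound 3 keeps neither the hydroxy of compound 2 nor the nitrile of compound 1, so its number is expected to fall between theirs, with a rise from compound 2 smaller than the measured step. The expected change is a 2.0-fold higher number from compound 2 to compound 3 (0.31 log units; beyond the scatter) in this estimate. For compound 3 the estimated value is 1200 ng.h/mL, with an expected range from 450 ng.h/mL to 3000 ng.h/mL in this assay.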

Compound 3, area under the concentration-time curve: 1000 ng.h/mL
For compound 3 the middle estimate is 1.2-fold (0.08 log units) above the measured one; the range from low to high includes it.
By their numbers in this assay, from the lowest: compounds 2, 3 and 1 (each within the scatter of the next, the first and the last beyond it).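

In this assay, taking the hydroxy off the aromatic carbon gives a 1.7-fold higher number from compound 2 to compound 3 (0.23 log units; within the scatter), and taking the nitrile off gives a 2.0-fold lower number from compound 1 to compound 3 (0.30 log units; within the scatter), so at this level of scatter neither group can be told apart from plain hydrogen on this ring. The earlier step, a 3.4-fold lower number from compound 1 to compound 2 (0.53 log units; beyond the scatter), lay beyond the scatter, yet the unsubstituted phenyl of compound 3 separates from neither of its neighbours, and that step therefore cannot be assigned to the loss of the nitrile alone or to the gain of the hydroxy alone; only the two substituted compounds stand apart from each other. Nothing in hand explains why the numbers fall as they do.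

The three compounds leave open whether another group on this ring, such as a methoxy, a fluorine or a carboxylic acid, would move the number beyond the scatter from the phenyl of compound 3. They also leave open whether the pattern in this assay would hold if the hydroxy on the shared core or the amine side chain were different.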